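Formyl replacing phenyl on the triazole-linked aryl ring

The compounds below may be only part of what the source reports. "The series", "measured", "known", "first", "only" and "open" are said of these compounds alone.

Measured compounds:
- Compound 1, `COc1cc(/C=C/C(C)=O)ccc1OCc1cn(-c2ccccc2OC)nn1`: 25700 nM
- Compound 2, `COc1cc(/C=C/C(C)=O)ccc1OCc1cn(-c2ccc(-c3ccccc3)cc2)nn1`: 65300 nM

Both compounds were tested in a functional assay on HCT-116 cells (Homo sapiens) for antiproliferative activity, read by MTT assay, with a stated time of 48 h; on this read-out higher numbers stand for weaker inhibition and lower numbers for stronger inhibition. Compound 2 stands highest of the two numbers; its nearest neighbour is compound 1, whose number is lower by a margin beyond the usual scatter, so compound 2 is the weaker of the pair on this read-out.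

Compound 3, `COc1cc(/C=C/C(C)=O)ccc1OCc1cn(-c2ccc(C=O)cc2)nn1`, is not yet measured. It differs from compound 2 in one place: formyl in place of phenyl on an aromatic carbon. For the measured compounds named here, a large ring-bearing group gives way to a small group holding a carbonyl, a change for which no measured pair exists here.

Because compound 2 gives 65300 nM and compound 1 gives 25700 nM, both in the weak range, the step to compound 3 is expected to be modest, with a slight lean towards a lower number, although a change no larger than the scatter would not surprise. For compound 3 the estimate is 35000 nM, with a range from 12000 nM to 100000 nM, which means an expected step of a 1.9-fold lower number from compound 2 to compound 3 (0.27 log units; within the scatter).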

Compound 3, half-maximal inhibitory concentration: 76200 nM
For compound 3 the middle estimate is 2.2-fold (0.34 log units) below the measured one; the range from low to high includes it.
By their numbers in this assay, from the lowest: compound 1; then compounds 2 and 3 (each within the scatter of the next).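

In this assay, formyl in place of phenyl on this aromatic carbon, para to a large group, gives a 1.2-fold higher number from compound 2 to compound 3 (0.07 log units; within the scatter), so a group of 2 heavy atoms without a ring and a group of 6 heavy atoms with an aromatic ring cannot be told apart on this read-out. The position therefore shows no sign of depending on the ring of phenyl, at least for this one pair of groups, whereas 4-formylphenyl in place of 2-methoxyphenyl on the aromatic nitrogen gives a 3.0-fold higher number from compound 1 to compound 3 (0.47 log units; beyond the scatter), a modest step beyond the scatter that leaves compound 1 with the lowest number of the three. Nothing available here explains why phenyl and formyl read alike.

The step from compound 1 to compound 3 changes both the substituent and the place it occupies on the ring, so these compounds cannot show which of the two matters, or whether a methoxy group at the place formyl holds would bring the number down. From the compounds shown here alone, it also remains open whether a group of another kind at this position, such as an amine or a carboxylic acid, would move the number beyond the scatter at all.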